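The compounds below may be only part of what the source reports. "The series", "measured", "known", "first", "only" and "open" are said of these compounds alone.

Measured compounds in a functional assay on PC-3 cells (Homo sapiens) for antiproliferative activity, read by MTT assay, with a stated time of 48 h; on this read-out lower numbers stand for stronger inhibition and higher numbers for weaker inhibition:
compound 1 `Cc1nnc(Sc2cc(NC(=O)c3ccc(Cl)cc3)c3ccccc3c2O)s1` gives 49500 nM
compound 2 `O=C(Nc1cc(Sc2ncnc3nc[nH]c23)c(O)c2ccccc12)c1ccc(Cl)cc1` gives 66400 nM
compound 3 `COc1ccc(C(=O)Nc2cc(Sc3ncn[nH]3)c(O)c3ccccc23)cc1` gives > 100000 nM

Compound 3 stands at the limit of this assay: its value is not a number but the limit (the limit of > 100000 nM in this assay, at which 1 of the 3 values shown sits), the weakest read-out among the three compounds. Compound 1 and compound 2, both carrying a 4-chlorophenyl on the amide, return numbers below that limit.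

The step from compound 3 to compound 4 `O=C(Nc1cc(Sc2ncn[nH]2)c(O)c2ccccc12)c1ccc(Cl)cc1` is chloro in place of methoxy on an aromatic carbon. For the measured compounds named here, the one measured step, a 1.3-fold higher number from compound 1 to compound 2 (0.13 log units; within the scatter), alters the group on the sulfur and leaves the benzamide untouched, so it gives no reading on a change at the para position of the phenyl ring. What remains is that the two measured compounds with the 4-chlorophenyl, compound 1 and compound 2, sit below the limit, whereas compound 3 with the 4-methoxyphenyl does not.

On that basis compound 4 is expected to come in below the limit, in the region of compound 1 and compound 2 in this assay, and the step of an at least 1.2-fold lower number from compound 3 to compound 4 (0.09 log units; that floor lies within the scatter) is the estimated size of the change. For compound 4 the estimate is 80000 nM, with a range from 40000 nM to 200000 nM, and a real chance that the assay again reports only a limit.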

Compound 4, half-maximal inhibitory concentration: 5520 nM
Estimate against measurement, compound 4: 14-fold (1.16 log units) above; measured number below the stated range.
By their numbers in this assay, from the lowest: compound 4; then compounds 1 and 2 (each within the scatter of the next). At a limit, above all of these: compound 3.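

In this assay, with the 1H-1,2,4-triazol-5-yl held on the sulfur, going from 4-methoxyphenyl to 4-chlorophenyl is a large change at this position, para to a large group: an at least 18-fold lower number from compound 3 to compound 4 (1.25 log units; beyond the scatter). With the 4-chlorophenyl held, the group on the sulfur also counts, which the earlier pair on that sulfur did not show: the 1H-1,2,4-triazol-5-yl brings a 9.0-fold lower number from compound 1 to compound 4 (0.95 log units; beyond the scatter) in place of the 5-methyl-1,3,4-thiadiazol-2-yl, and a 12-fold lower number from compound 2 to compound 4 (1.08 log units; beyond the scatter) in place of the group of 9 heavy atoms. Compound 3 is read only as a limit and not as a number, so the step from it gives a floor and not a size: the limit of > 100000 nM in this assay, at which 1 of the 4 values shown sits.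

Still open, going by these compounds, is whether chloro does as much with the other groups on the sulfur, since the 4-methoxyphenyl is paired here with the 1H-1,2,4-triazol-5-yl alone. Also open, on these data alone, is how the read-out answers to other groups at the same place on the ring, such as fluoro, methyl, trifluoromethyl or an amine, and whether chloro is specifically needed there.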